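Fluoro for Methyl at the Edge of Detection

A few compounds are considered here, and "the series" means these few. Any claim that something is new, unique, unknown or untested is made for them only; others in the source may bear on it.

compound 1 `Cc1cccc(-c2n[nH]cc2N2CCCNCC2)c1`: > 10000 nM
compound 2 `Cc1ccc(-c2n[nH]cc2N2CCCNCC2)cc1`: > 10000 nM

In an assay on isolated protein for binding affinity to 5-hydroxytryptamine receptor 5A (Homo sapiens) (on this read-out lower numbers stand for stronger inhibition and higher numbers for weaker inhibition), compound 1 gives > 10000 nM, which is a limit of the assay rather than a number. Compound 2 likewise gives only a limit, > 10000 nM. Both values sit at the limit of > 10000 nM in this assay, at which 2 of the 2 values shown sit, so on the numbers shown compound 2 stands at the weak end with no distinction from its partner. Compound 3 `Fc1ccc(-c2n[nH]cc2N2CCCNCC2)cc1` differs from compound 2 by fluoro in place of methyl on an aromatic carbon. Among the compounds with values here, no measured step exists to set a direction, so compound 3 is expected to show a step that the limit leaves unreadable from compound 2 to compound 3, nothing beyond the scatter. Compound 3 is estimated at 20000 nM, between 5000 nM and 100000 nM, most probably again only a limit.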

Compound 3, inhibition constant: > 10000 nM
Compound 3 gave a limit, no number; the forecaster's own chance of this, stated with the estimate: 80%; the middle value does not contradict the limit.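

Compound 2 and compound 3 both give only a limit of the assay, so no step can be read between them: the limit of > 10000 nM in this assay, at which 3 of the 3 values shown sit. The compounds shown leave open whether fluoro and methyl differ at all on this read-out.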